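This account rests on a few compounds, and the source may have more. Where it says the series, first, only, none or still open, it means among the compounds named here.

Working notes on the series in an assay on CHO cells for binding affinity to Alpha-2C adrenergic receptor (Homo sapiens), read by radioligand binding; a higher number here means a weaker inhibitor, a lower number a stronger inhibitor.

Compound 1 `CS(=O)(=O)c1cc(F)ccc1NCC1=NCCN1` gives only a limit in this assay, < 5020 nM, with the limit of < 5020 nM in this assay, at which 1 of the 3 values shown sits, marking where it sits. Compound 2 `CSc1cc(F)ccc1NCC1=NCCN1` gives 219 nM in this assay. The change between them is methylsulfanyl in place of methylsulfonyl on an aromatic carbon, and the step that the limit leaves unreadable from compound 1 to compound 2 cannot be sized because compound 1 is a limit. Compound 3 `CS(=O)(=O)c1ccc(Cl)cc1NCC1=NCCN1` gives 4790 nM in this assay, the highest number among the measured compounds; how the core of compound 3 differs from the core of compound 1 is not broken down here.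

Compound 4 `CSc1ccc(Cl)cc1NCC1=NCCN1` is not yet measured. It differs from compound 3 by methylsulfanyl in place of methylsulfonyl on an aromatic carbon, the same kind of change as from compound 1 to compound 2, but around a different place: meta to a fluoro group in one case, para to a chloro group in the other. The earlier step being unreadable, the expectation for compound 4 rests on compound 2 at 219 nM carrying the same methylsulfanyl group. A step of a 12-fold lower number from compound 3 to compound 4 (1.08 log units; beyond the scatter) is estimated from compound 3, and compound 4 is expected near 400 nM, within 100 nM to 1600 nM.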

Compound 4, inhibition constant: 170 nM
For compound 4 the middle estimate is 2.4-fold (0.37 log units) above the measured one, and the stated range covers the measured number.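

In this assay, methylsulfanyl in place of methylsulfonyl on an aromatic carbon, para to a chloro group, gives a 28-fold lower number from compound 3 to compound 4 (1.45 log units; beyond the scatter), so on the core of compound 3 the change has a readable size and direction. The same change on the core of compound 1 has no readable size, because that compound gives only a limit: the limit of < 5020 nM in this assay, at which 1 of the 4 values shown sits. The series therefore gives the size of this change on one core only, and it does not show whether a step of that size carries over from one core to the other, nor that the change depends on the core.

Open, on these data alone, is how methylsulfinyl, which has one oxygen fewer than methylsulfonyl, would read on either core, and whether a longer chain such as ethylsulfanyl would keep the number reached by compound 4 at 170 nM. Also open, as far as these compounds go, is how an amine or a carboxylic acid would read on an aromatic carbon at the same place.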